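The source may report more compounds than this note shows. Statements on the series, on what has been measured and on what is new or still open speak of the compounds shown alone.

Measured compounds:
- compound 1 `COc1ccc(C(=O)Nc2ccccc2SC)cc1OC1CCCC1`: 1200 nM
- compound 2 `COc1ccc(C(=O)Nc2ccncc2)cc1OC1CCCC1`: 800 nM
- compound 3 `COc1ccc(C(=O)NN2C(Cl)=NC=CC2Cl)cc1OC1CCCC1`: 400 nM

In an assay on isolated protein for inhibition of phosphodiesterase 4A (Sus scrofa) (a lower number here means a stronger inhibitor, a higher number a weaker inhibitor), compound 3 gives the smallest number of the three. Against compound 1 this holds, as a 3.0-fold lower number from compound 1 to compound 3 (0.48 log units; beyond the scatter) is beyond the scatter; against compound 2 it does not, as a 2.0-fold lower number from compound 2 to compound 3 (0.30 log units; within the scatter) stays within it. Compound 4 `COc1ccc(C(=O)NC2(C)C=C(C)ON2)cc1OC1CCCC1` differs from compound 3 by a group of 7 heavy atoms (5 carbon, 1 nitrogen, 1 oxygen; one five-membered non-aromatic ring with 2 hetero atoms) in place of a group of 8 heavy atoms (4 carbon, 2 nitrogen, 2 chlorine; one six-membered non-aromatic ring with 2 hetero atoms), on an amide-type nitrogen. Every measured step also swapped the group on that amide-type nitrogen: a 1.5-fold lower number from compound 1 to compound 2 (0.18 log units; within the scatter), a 2.0-fold lower number from compound 2 to compound 3 (0.30 log units; within the scatter) and a 3.0-fold lower number from compound 1 to compound 3 (0.48 log units; beyond the scatter). None of these moved the number far, so for this assay a step of no more than modest size is expected, in either direction. Compound 4 is therefore estimated at 600 nM, within 250 nM to 1500 nM, which would mean an expected 1.5-fold higher number from compound 3 to compound 4 (0.18 log units; within the scatter).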

Compound 4, half-maximal inhibitory concentration: 450 nM
Estimate against measurement, compound 4: 1.3-fold (0.12 log units) above; the range from low to high includes it.
By their numbers in this assay, from the lowest: compounds 3, 4, 2 and 1 (each within the scatter of the next, the first and the last beyond it).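

In this assay, a five-membered non-aromatic ring with 2 hetero atoms, the first such ring shown on the amide-type nitrogen, gives a 1.1-fold higher number from compound 3 to compound 4 (0.05 log units; within the scatter) and a 1.8-fold lower number from compound 2 to compound 4 (0.25 log units; within the scatter), both within the scatter. Only a 2.7-fold lower number from compound 1 to compound 4 (0.43 log units; beyond the scatter) goes beyond it, and only modestly, so this position holds a five-membered ring as well as the six-membered rings without a large shift in the number. No measured evidence explains these numbers. The compounds shown leave open whether an amine, a carboxylic acid or a longer chain on that nitrogen would move the number further.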